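An Ethyl Ester Variant of a Phosphate Prodrug in Blood

The source may hold more compounds than are shown below. What is called first, only, known or untested is meant among the compounds shown, and "the series" means these compounds.

Compound 1 `CC(C)(C)C(=O)OCO[P@@]1(=O)OCC(C)(C)[C@H](C(=O)NCCC(=O)O)O1` carries a free carboxylic acid at the end of its side chain. In an ADME assay on blood (Homo sapiens) for pharmacokinetics (a higher number here means that the compound lasts longer, a lower number that the compound disappears faster), compound 1 reaches > 1 h, which is a limit of the assay and not a number. Two further compounds share the same core. Compound 2 `COC(=O)CCNC(=O)[C@@H]1O[P@](=O)(OCOC(=O)c2ocnc2C)OCC1(C)C` gives 0.27 h in this assay. Compound 3 `COC(=O)CCNC(=O)[C@@H]1OP(=O)(Oc2ccc(F)cc2)OCC1(C)C` comes out at > 1 h, again a limit rather than a number. Compound 1 therefore stands at the limit of > 1 h in this assay, at which 2 of the 3 values shown sit, together with compound 3, while compound 2 is the only one of the three with a measured number, and that number falls short of the limit.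

The unmeasured compound 4 `CCOC(=O)CCNC(=O)[C@@H]1O[P@@](=O)(OCOC(=O)C(C)(C)C)OCC1(C)C` differs from compound 1 in a single place: ethyl in place of hydrogen on an oxygen next to a carbonyl group. For the measured compounds named here, no step between two measured compounds is available, so the size of this change can only be expected. Compound 4 is expected to give a measured number in this assay because compound 2 with an ester on that oxygen gives 0.27 h. The step from compound 1 to compound 4 is estimated at an at least 2.0-fold lower number from compound 1 to compound 4 (0.30 log units; that floor lies within the scatter). The half-life of compound 4 is estimated at 0.5 h, within a range from 0.2 h to 1.5 h.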

Compound 4, half-life: 0.28 h
Compound 4: the middle estimate sits 1.8-fold (0.25 log units) above what was measured, and the stated range covers the measured number.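

For the compounds shown here, with the rest of compound 1 unchanged, the move from carboxy to ethoxycarbonyl gives the first step between two compounds that differ in one place in this assay: an at least 3.5-fold lower number from compound 1 to compound 4 (0.55 log units; beyond the scatter). In this assay compound 1 gives > 1 h, which is a limit of the assay and not a number. The step is thus a floor that already lies beyond the scatter, showing that ethyl in place of hydrogen on this oxygen matters here, while its full size cannot be read, with the upper end of the values shared by two compounds: the limit of > 1 h in this assay, at which 2 of the 4 values shown sit.

The compounds shown leave open how a longer chain in place of the ethyl, or an amide in place of the ester, would read in this assay at this position. They also leave open whether the same change from carboxy to ethoxycarbonyl gives a step of similar size when a different group, such as the fluorophenyl ether of compound 3, sits on the phosphorus.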